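This account rests on a few compounds, and the source may have more. Where it says the series, first, only, none or still open, it means among the compounds named here.

Measured compounds:
- compound 1, `CCC(CC)n1c(-c2ccc(OCc3c(-c4c(Cl)cccc4Cl)noc3C(C)C)cc2)nc2ccc(C(=O)O)cc21`: 0.8 nM
- compound 2, `CC(C)c1onc(-c2c(Cl)cccc2Cl)c1COc1ccc(-c2nc3ccc(C(=O)O)cc3n2-c2ccc(F)cc2)cc1`: 32.2 nM

The study follows a series that shares one core and varies the group on an aromatic nitrogen. In an assay on Huh-7 cells for agonist activity at Bile acid receptor (Homo sapiens), read by a luciferase reporter (on this read-out lower numbers stand for an effect already at smaller amounts and higher numbers for an effect only at larger amounts of compound), compound 1 gives 0.8 nM, the lowest number of the two measured compounds. Among the compounds with values here, its nearest neighbour is compound 2, which in this assay gives 32.2 nM; the single measured step, a 40-fold higher number from compound 1 to compound 2 (1.60 log units; beyond the scatter), is large and well beyond the scatter.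

Compound 3, `CC(=O)N1CCC(n2c(-c3ccc(OCc4c(-c5c(Cl)cccc5Cl)noc4C(C)C)cc3)nc3ccc(C(=O)O)cc32)CC1`, has not yet been measured. It differs from compound 1 in one place: 1-acetylpiperidin-4-yl in place of pentan-3-yl on an aromatic nitrogen. Within the data shown here, only one measured step bears on this change, namely a 40-fold higher number from compound 1 to compound 2 (1.60 log units; beyond the scatter), in which a flat aromatic group replaced the pentan-3-yl. The group entering in compound 3 is a saturated six-membered ring bearing an acetyl, closer in shape to the branched pentan-3-yl than the 4-fluorophenyl was, so a loss of the same size is not expected. A modest rise in the number, at the edge of the scatter, is expected: a 3.1-fold higher number from compound 1 to compound 3 (0.49 log units; beyond the scatter). For compound 3 in this assay the estimate is 2.5 nM, with a range from 0.8 nM to 10 nM.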

Compound 3, half-maximal effective concentration: 1430 nM
For compound 3 the middle estimate is 570-fold (2.76 log units) below the measured one, outside the stated range (above it).
By their numbers in this assay, from the lowest: compound 1; then compound 2; then compound 3.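

In this assay the exchange of pentan-3-yl for 1-acetylpiperidin-4-yl gives a 1800-fold higher number from compound 1 to compound 3 (3.25 log units; beyond the scatter) and is the largest step seen at this aromatic nitrogen, so a non-aromatic ring here does not by itself keep the low number of compound 1. The step of a 44-fold higher number from compound 2 to compound 3 (1.65 log units; beyond the scatter) also places the 1-acetylpiperidin-4-yl group behind the 4-fluorophenyl group, which means that the earlier loss on going to an aromatic ring was not the greatest this position can show, and that the three groups on this nitrogen spread the numbers widely on an otherwise shared core. Nothing available explains why this group costs so much more than either of the other two.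

The compounds shown leave open whether the loss belongs to the six-membered ring, to the ring nitrogen or to the acetyl, since all three enter together in compound 3. A cyclohexyl group or a piperidin-4-yl group without the acetyl on this aromatic nitrogen would separate these parts, and a smaller branched chain such as propan-2-yl would show how closely the low number depends on pentan-3-yl itself.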